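The source may hold more compounds than are shown below. What is called first, only, known or untested is meant among the compounds shown, and "the series" means these compounds.

Measured compounds in a functional assay on SGC-7901 cells (Homo sapiens) for antiproliferative activity, read by MTT assay, with a stated time of 72 h; a higher number here means a weaker inhibitor, a lower number a stronger inhibitor:

- compound 1, `COc1cc(-c2ccc3ncn(-c4cc(OC)c(OC)c(OC)c4)c3c2)cc(OC)c1OC`: > 10000 nM, which is a limit of the assay and not a number
- compound 2, `COc1ccccc1-c1ccc2ncn(-c3cc(OC)c(OC)c(OC)c3)c2c1`: 5050 nM
- compound 3, `COc1cc(-n2cnc3ccc(-c4cccc(C)c4)cc32)cc(OC)c1OC`: 1240 nM

Compound 2 stands as the highest of the two numbers shown in this assay; its nearest neighbour is compound 3, reached by a 4.1-fold lower number from compound 2 to compound 3 (0.61 log units; beyond the scatter), a modest step that is beyond the scatter. Among the compounds with values here, the only other value, that of compound 1, is a limit of the assay and gives no number to compare with.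

Compound 4, `CCOc1ccc(-c2ccc3ncn(-c4cc(OC)c(OC)c(OC)c4)c3c2)cc1`, has not yet been measured. It differs from compound 2 in one place: 4-ethoxyphenyl in place of 2-methoxyphenyl on an aromatic carbon. Within the data shown here, the one measured step that touches the same position is the change from compound 2 to compound 3, where a 3-methylphenyl in place of the 2-methoxyphenyl gave a 4.1-fold lower number from compound 2 to compound 3 (0.61 log units; beyond the scatter). Among the measured compounds shown here, no measured pair shows a 4-ethoxyphenyl or any other group placed on that ring in the same way, so the direction for compound 4 is not settled by the data; the step from compound 2 to compound 3 suggests that moving away from the 2-methoxyphenyl need not be harmful, and a downward movement of roughly the same order is plausible but not secure.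

On that basis compound 4 is expected to sit at about 3000 nM in this assay, with a range of 800 nM to 12000 nM, which would mean an estimated step of a 1.7-fold lower number from compound 2 to compound 4 (0.23 log units; within the scatter).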

Compound 4, half-maximal inhibitory concentration: 2970 nM
Beside the measured number, compound 4's estimate is 1.0-fold (0.00 log units) above it, and the stated range covers the measured number.
By their numbers in this assay, from the lowest: compound 3; then compounds 4 and 2 (each within the scatter of the next). At a limit, above all of these: compound 1.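

In this assay, this aromatic carbon of the shared core accepts 4-ethoxyphenyl in place of 2-methoxyphenyl with no change that can be told from the scatter, as the step shows: a 1.7-fold lower number from compound 2 to compound 4 (0.23 log units; within the scatter). Within the data shown here, the earlier compounds offered only one numerical step at this position, so this is the first sign that the ether-bearing phenyl group can differ in both chain and placement while its number stays within the scatter. The 3-methylphenyl group keeps its separation from the new group, with a 2.4-fold higher number from compound 3 to compound 4 (0.38 log units; beyond the scatter) as a modest step, so among the three compounds with numbers, compound 3 alone stands clear of the other two.

Open questions are whether an amine, a carboxylic acid or a chain longer than ethoxy on this phenyl ring would change the number, and how far the ethoxy chain and its placement on the ring each count, since 4-ethoxyphenyl changes both at once. No measurement shown here bears on why the numbers at this position differ.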